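This account rests on a few compounds, and the source may have more. Where it says the series, first, only, none or still open, it means among the compounds named here.

Of the compounds shown here, three built on one shared core have been tested in a functional assay on cells (blood, Homo sapiens) for inhibition, read by chemiluminescence, with a stated time of 30 min; on this read-out higher numbers stand for weaker inhibition and lower numbers for stronger inhibition. Compound 1 `CC1(C)CC(=O)C(C(=S)SCCO)=C(Nc2ccc(Cl)cc2)C1` gives > 100 ug/mL, which is a limit of the assay and not a number. Compound 2 `CCCCSC(=S)C1=C(Nc2ccc(Br)cc2)CC(C)(C)CC1=O` likewise gives > 100 ug/mL, again a limit. Compound 3 `CCCCCCCCCCCSC(=S)C1=C(Nc2ccc(Br)cc2)CC(C)(C)CC1=O` gives > 100 ug/mL, once more only a limit, so compound 3 stands at the edge of what this assay can report, with no number of its own. Going by the values given here, the only step between measured compounds, a step that the two limits leave unreadable from compound 2 to compound 3, introduces heptyl in place of hydrogen on a saturated chain carbon, four bonds along the chain from a sulfur; with both ends at a limit, its size cannot be read.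

Compound 4 `CC1(C)CC(=O)C(C(=S)SCCO)=C(Nc2ccc(Br)cc2)C1` differs from compound 3 in one place: hydroxy in place of nonyl on a saturated chain carbon, two bonds along the chain from a sulfur. Among the compounds with values here, no measured step covers this change, and the one step available gives no size. Because the limit of > 100 ug/mL in this assay, at which 3 of the 3 values shown sit, holds for every value shown, no movement beyond the scatter is expected in this assay. The step that the limit leaves unreadable from compound 3 to compound 4 is therefore estimated to be essentially flat. Compound 4 is expected to give about 150 ug/mL, with a range from 60 ug/mL to 400 ug/mL.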

Compound 4, half-maximal inhibitory concentration: > 100 ug/mL
Compound 4 was reported as a limit (the forecaster's own chance of this, stated with the estimate: 85%); the middle value lies beyond the limit too.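

In this assay compound 4 gives > 100 ug/mL, a limit of the assay and not a number. The steps from compound 1, compound 2 and compound 3 to compound 4 therefore cannot be read: the limit of > 100 ug/mL in this assay, at which 4 of the 4 values shown sit.

The compounds shown leave open whether changing the sulfur chain, or bromo against chloro, alters inhibition at all.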